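A Benzyloxy Group Added to a Compound at the Limit

The compounds below may be only part of what the source reports. "The series", "measured", "known", "first", "only" and "open" are said of these compounds alone.

In a functional assay on A549 cells (Homo sapiens) for cytotoxicity, read by MTT assay, with a stated time of 72 h (a higher number here means a weaker inhibitor, a lower number a stronger inhibitor), compound 3 `CCOC(=O)c1c(C)oc2ncnc(Nc3ccccc3)c12` gives > 1000000 nM, which is a limit of the assay and not a number. Compound 1 `CCOC(=O)c1c(C)oc2ncnc(Nc3cccc(C)c3)c12` gives > 1000000 nM, also a limit. Compound 2 `CCOC(=O)c1c(C)oc2ncnc(Nc3cccc(Br)c3)c12` gives > 1000000 nM, again a limit. The whole set therefore rests on (the limit of > 1000000 nM in this assay, at which 3 of the 3 values shown sit).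

The next compound is compound 4 `CCOC(=O)c1c(C)oc2ncnc(Nc3ccc(OCc4ccccc4)cc3)c12`, and its difference from compound 3 is benzyloxy in place of hydrogen on an aromatic carbon. In words, benzyloxy takes the place of hydrogen on an aromatic carbon.

The closest measured changes also exchange one group for another on an aromatic carbon, although none of them brings in benzyloxy. They are a step that the two limits leave unreadable from compound 1 to compound 3, a step that the two limits leave unreadable from compound 2 to compound 3 and a step that the two limits leave unreadable from compound 1 to compound 2. None of these has a readable size, so they lend no figure to carry over to the new change. Any expectation is thus a loose one: a shift towards stronger inhibition is possible, but compound 4 may equally remain at the limit of this assay.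

The expected change is an at least 3.3-fold lower number from compound 3 to compound 4 (0.52 log units; beyond the scatter). For compound 4 the estimated value is 300000 nM, with an expected range from 20000 nM to 1000000 nM.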

Compound 4, half-maximal inhibitory concentration: > 1000000 nM
Compound 4: no number, only a limit (the forecaster's own chance of this, stated with the estimate: 60%); at least 3.3-fold (0.52 log units) between middle value and limit.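

In this assay compound 4 gives > 1000000 nM, which is a limit of the assay and not a number. No size can therefore be read for the change from compound 3 to compound 4, as the whole set sits at one limit: the limit of > 1000000 nM in this assay, at which 4 of the 4 values shown sit.

The compounds shown leave open whether any group on this shared core can bring a readable value in this assay.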